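Working notes: substituent swap from compound 3 to compound 4

The source may report more compounds than this note shows. Statements on the series, on what has been measured and on what is new or still open speak of the compounds shown alone.

Measured in an ADME assay on the whole organism with Oryza sativa as the target, tested at 10 uM; on this read-out lower numbers stand for a stronger effect and higher numbers for a weaker effect at the one concentration tested:
compound 1, `C[C@@H](NC(=O)Nc1ccccc1C(C)(C)C)c1ccccc1`: 17%
compound 2, `C[C@@H](NC(=O)Nc1ccccc1C(F)(F)F)c1ccccc1`: 54%
compound 3, `COc1ccccc1NC(=O)N[C@H](C)c1ccccc1`: 96%

Compound 3 stands highest of the three numbers; the nearest is compound 2, with a number 42 percentage points higher from compound 2 to compound 3 (beyond the scatter), and the furthest compound 1, with a number 79 percentage points higher from compound 1 to compound 3 (beyond the scatter).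

Compound 4, `CC(=O)c1ccccc1NC(=O)N[C@H](C)c1ccccc1`, differs from compound 3 by acetyl in place of methoxy on an aromatic carbon. Every measured step concerns this same aromatic carbon: a number 37 percentage points higher from compound 1 to compound 2 (beyond the scatter), a number 79 percentage points higher from compound 1 to compound 3 (beyond the scatter) and a number 42 percentage points higher from compound 2 to compound 3 (beyond the scatter), each large. With compound 3 already at 96%, the top of the range, a further swap at this position is expected to move the number downward in this assay, beyond the scatter. For compound 4 a step of a number 26 percentage points lower from compound 3 to compound 4 (beyond the scatter) is estimated. Compound 4 is therefore expected to give 70%, within 35% to 98%.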

Compound 4, a percentage reported as activity, at one concentration (the size of the read-out at that concentration, not a potency): 89%
Compound 4: the middle estimate sits 19 percentage points below what was measured, and the stated range covers the measured number.
By their numbers in this assay, from the lowest: compound 1; then compound 2; then compounds 4 and 3 (each within the scatter of the next).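

Acetyl and methoxy cannot be told apart on this aromatic carbon (a number 7 percentage points lower from compound 3 to compound 4 (within the scatter)), so a second oxygen-bearing group, here with a carbonyl, sits at the same level as the first. Compound 4 stays well clear of the other two groups (a number 35 percentage points higher from compound 2 to compound 4 (beyond the scatter); a number 72 percentage points higher from compound 1 to compound 4 (beyond the scatter)). Nothing available explains this grouping.

Going by these compounds, whether an amine, a carboxylic acid or a longer chain on this carbon would stay with methoxy and acetyl or fall nearer tert-butyl remains open. So does whether the grouping holds at other ring positions.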